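Solubility notes: triazole replaces thiazolidinedione on the chain

A few compounds are considered here, and "the series" means these few. Any claim that something is new, unique, unknown or untested is made for them only; others in the source may bear on it.

Compound 2 `O=C1CSC(=O)N1C[C@H]1CN(c2ccc(-n3cc(-c4ccccn4)cn3)c(F)c2)C(=O)O1` gives 26900 nM in a physicochemical assay for solubility, read by HPLC, with a stated time of 24 h; a higher number here means a more soluble compound, a lower number a less soluble compound. Compound 1 `O=C1O[C@@H](CN2CCC(O)CC2)CN1c1ccc(-n2cc(-c3ccccn3)cn2)c(F)c1` gives 45900 nM in this assay, and the step of a 1.7-fold lower number from compound 1 to compound 2 (0.23 log units; within the scatter) lies within the scatter, so the two numbers are not separated. Compound 3 `O=C1O[C@@H](Cn2ccnn2)CN1c1ccc(-n2cc(-c3ccccn3)cn2)c(F)c1` carries the change (1H-1,2,3-triazol-1-yl in place of 2,4-dioxo-1,3-thiazolidin-3-yl on a saturated chain carbon bound to a saturated ring carbon). Among the compounds with values here, the only measured step touches the same carbon but brings in a different group, and it stayed within the scatter; on that basis the step of a 1.3-fold higher number from compound 2 to compound 3 (0.11 log units; within the scatter) is expected to stay within the scatter too. Compound 3 is estimated at 35000 nM, with a range of 15000 nM to 80000 nM.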

Compound 3, solubility: 247000 nM
Estimate against measurement, compound 3: 7.1-fold (0.85 log units) below; measured number above the stated range.
By their numbers in this assay, from the lowest: compounds 2 and 1 (each within the scatter of the next); then compound 3.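

This saturated chain carbon can carry a change that moves the number in this assay beyond the scatter: 1H-1,2,3-triazol-1-yl gives a 9.2-fold higher number from compound 2 to compound 3 (0.96 log units; beyond the scatter) and also a 5.4-fold higher number from compound 1 to compound 3 (0.73 log units; beyond the scatter). Both departing groups, one a non-aromatic ring with two double bonds outside it and the other 4-hydroxypiperidin-1-yl, give a step in the same direction. No available evidence bears on the reason for this result.

From the compounds shown here alone, whether the higher number goes with the aromatic ring or with its three nitrogens remains open. A 1H-imidazol-1-yl or a 1H-1,2,4-triazol-1-yl on this carbon would separate those two readings.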